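The source may report more compounds than this note shows. Statements on the series, on what has been measured and on what is new or still open speak of the compounds shown alone.

Series notes. In a functional assay on HT-29 cells (Homo sapiens) for cytotoxicity, read by MTT assay, with a stated time of 24 h (on this read-out lower numbers stand for stronger inhibition and higher numbers for weaker inhibition), compound 1 `C#CCOc1cc(N(CC)CC)ccc1/C=N/Cc1ccc(S(N)(=O)=O)cc1` gives 62800 nM and compound 2 `C#CCOc1ccc([N+](=O)[O-])cc1/C=N/Cc1ccc(S(N)(=O)=O)cc1` gives 34800 nM. Compound 3 `O=Cc1cccc(OCc2cn(CCCOc3ccc4ccc(=O)oc4c3)nn2)c1` gives 129000 nM in this assay, the highest of the three numbers; its nearest neighbour is compound 1 and its furthest is compound 2, and both gaps lie beyond the usual scatter, so compound 3 is the weakest of the set on this read-out.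

Compound 4 `COc1cccc(C=O)c1OCc1cn(CCCOc2ccc3ccc(=O)oc3c2)nn1` has not been measured. It differs from compound 3 by 2-formyl-6-methoxyphenyl in place of 3-formylphenyl on an oxygen on a saturated carbon. For the measured compounds named here, no measured pair in the set shares this change, so there is nothing to calibrate its size against. The change keeps a formyl group and adds a methoxy group; with all three measured numbers already sitting in the weak range, no step beyond the scatter is expected in either direction. The expected step from compound 3 to compound 4 is a 1.1-fold lower number from compound 3 to compound 4 (0.03 log units; within the scatter). Compound 4 is estimated at 120000 nM, with a range from 50000 nM to 300000 nM, and a real chance that the read-out reports only a limit at this level.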

Compound 4, half-maximal inhibitory concentration: 13300 nM
Beside the measured number, compound 4's estimate is 9.0-fold (0.96 log units) above it, outside the stated range (below it).
By their numbers in this assay, from the lowest: compound 4; then compounds 2 and 1 (each within the scatter of the next); then compound 3.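

In this assay, the place on an oxygen on a saturated carbon proves responsive to the aryl group it carries, with a 9.7-fold lower number from compound 3 to compound 4 (0.99 log units; beyond the scatter) when 2-formyl-6-methoxyphenyl replaces 3-formylphenyl. For the compounds shown here, this is the only step in the set between compounds that differ in one place, so it gives the first measure of how far a single change can shift this read-out. No measurement shown accounts for the size of this step.

The compounds shown do not separate the added methoxy group from the changed formyl position, as both enter in the same step. Also open, going by these compounds, is whether a hydroxyl or an ethoxy group in place of the methoxy group would keep the number of compound 4 13300 nM or lose it.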